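The source may hold more compounds than are shown below. What is called first, only, known or untested is meant among the compounds shown, and "the series" means these compounds.

Three compounds share one core and differ only in the group carried on the saturated chain carbon three bonds along the chain from an aromatic carbon and a sulfur. Compound 1 `CC(=O)c1cccc(CC[C@H](SC[C@@H](C)C(=O)O)c2cccc(/C=C/c3ccc4ccc(Cl)cc4n3)c2)c1` carries a 3-acetylphenyl there, compound 2 `CC(=O)c1ccccc1CC[C@H](SC[C@@H](C)C(=O)O)c1cccc(/C=C/c2ccc3ccc(Cl)cc3n2)c1` a 2-acetylphenyl, and compound 3 `C[C@H](CS[C@@H](CCc1cccc(CO)c1)c1cccc(/C=C/c2ccc3ccc(Cl)cc3n2)c1)C(=O)O` a 3-(hydroxymethyl)phenyl. In an assay on membranes from lung for inhibition of cysteinyl leukotriene receptor 1 (Cavia porcellus) (on this read-out lower numbers stand for stronger inhibition and higher numbers for weaker inhibition), compound 1 gives 5.9 nM, compound 2 gives 3 nM, and compound 3 gives 2.1 nM. Compound 2 stands second highest of the three numbers; its nearest neighbour is compound 3 and its furthest is compound 1, and both gaps lie within the scatter. Moving the acetyl gave a 2.0-fold lower number from compound 1 to compound 2 (0.29 log units; within the scatter); exchanging it for hydroxymethyl gave a 2.8-fold lower number from compound 1 to compound 3 (0.45 log units; beyond the scatter); and the remaining comparison gave a 1.4-fold lower number from compound 2 to compound 3 (0.15 log units; within the scatter).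

Compound 4 `C[C@H](CS[C@@H](CCc1ccccc1C(=O)c1ccccc1)c1cccc(/C=C/c2ccc3ccc(Cl)cc3n2)c1)C(=O)O` keeps everything of compound 2 except one group: phenyl in place of methyl on a carbonyl carbon, that is, acetyl becomes benzoyl. For the measured compounds named here, none of the measured steps touches this carbonyl carbon, so they bear on it only loosely: every change tried so far at this end of the molecule moved the number by little, and only one of them went beyond the scatter. Compound 4 is therefore expected to show no step beyond the scatter, a 1.3-fold higher number from compound 2 to compound 4 (0.12 log units; within the scatter). The estimate for compound 4 in this assay is 4 nM, expected to fall between 1.5 nM and 12 nM.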

Compound 4, half-maximal inhibitory concentration: 4.3 nM
Estimate against measurement, compound 4: 1.1-fold (0.03 log units) below; the range from low to high includes it.
By their numbers in this assay, from the lowest: compounds 3, 2, 4 and 1 (each within the scatter of the next, the first and the last beyond it).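

Exchanging acetyl for benzoyl puts a phenyl of six heavy atoms on the carbonyl carbon where a methyl of one heavy atom stood, and in this assay this gives a 1.4-fold higher number from compound 2 to compound 4 (0.16 log units; within the scatter). For the compounds shown here, the earlier compounds moved the acetyl or replaced it with hydroxymethyl, whereas this pair is the first to change what sits on the carbonyl carbon itself, and it shows that an added aromatic ring there leaves the number within the scatter of compound 2. Nothing available explains why the number holds across so large a change in group size.

Only methyl and phenyl have been seen on this carbonyl carbon, both built of carbon alone, so the compounds shown do not tell whether an amine, which would turn the ketone into an amide, or a longer chain such as butyl would also leave the number in place. They also leave open whether benzoyl would behave in the same way in place of the acetyl of compound 1, where the group sits elsewhere on the ring.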